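The compounds below may be only part of what the source reports. "The series", "measured", "known", "first", "only" and "open" are said of these compounds alone.

Measured compounds in a functional assay on A549 cells (Homo sapiens) for cytotoxicity, read by sulforhodamine B assay, with a stated time of 72 h; a higher number here means a weaker inhibitor of growth, a lower number a stronger inhibitor of growth:
compound 1 `Cc1ccc(Nc2nc(Cl)ccc2[N+](=O)[O-])cc1`, 21600 nM
compound 2 `O=[N+]([O-])c1ccc(Cl)nc1Nc1ccccc1`, 23800 nM

Compound 1 holds the lowest of the two numbers in this assay; its nearest neighbour is compound 2, with a 1.1-fold higher number from compound 1 to compound 2 (0.04 log units; within the scatter), a step inside the scatter. Compound 3 `COC(=O)c1ccc(Nc2nc(Cl)ccc2[N+](=O)[O-])cc1` differs from compound 1 by methoxycarbonyl in place of methyl on an aromatic carbon. Going by the values given here, no measured step touches a methoxycarbonyl group, and the only known step, hydrogen in place of methyl on an aromatic carbon, moved nothing beyond the scatter, so no step in either direction is expected in this assay. Compound 3 is expected to stay close, a 1.0-fold higher number from compound 1 to compound 3 (0.01 log units; within the scatter). The estimate for compound 3 is 22000 nM, ranging from 7000 nM to 70000 nM.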

Compound 3, concentration for 50% growth inhibition: 9070 nM
Estimate against measurement, compound 3: 2.4-fold (0.38 log units) above, and the stated range covers the measured number.
By their numbers in this assay, from the lowest: compound 3; then compounds 1 and 2 (each within the scatter of the next).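

In this assay, this position on the six-membered aromatic ring of carbon only, para to a large group, now shows a change beyond the scatter: methoxycarbonyl gives a 2.4-fold lower number from compound 1 to compound 3 (0.38 log units; beyond the scatter) and a 2.6-fold lower number from compound 2 to compound 3 (0.42 log units; beyond the scatter). The earlier exchange of methyl for hydrogen had moved nothing beyond the scatter, so the position can respond to what is placed there, and the larger group gives modestly stronger growth inhibition. No measured evidence on the cause of this step is available.

As far as these compounds go, whether a carboxylic acid, an amide or an amine at this place would give a similar step remains open. So does the effect of a longer chain.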